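This account rests on a few compounds, and the source may have more. Where it says the series, first, only, none or still open, it means among the compounds named here.

Measured compounds:
- compound 1 `Cc1noc(NS(=O)(=O)c2ccc(N/C(S)=N\c3ccnc4cc(C(F)(F)F)ccc34)cc2)c1C` — 36800 nM
- compound 2 `O=S(=O)(Nc1ccccn1)c1ccc(N/C(S)=N\c2ccnc3cc(C(F)(F)F)ccc23)cc1` — 28000 nM
- compound 3 `O=S(=O)(Nc1ncccn1)c1ccc(N/C(S)=N\c2ccnc3cc(C(F)(F)F)ccc23)cc1` — 42100 nM

All three share a core and differ only in the group on the sulfonamide nitrogen. In a functional assay on HepG2 cells (Homo sapiens) for antiproliferative activity, read by sulforhodamine B assay, with a stated time of 48 h (a higher number here means a weaker inhibitor, a lower number a stronger inhibitor), compound 3 gives the highest of the three numbers, but its neighbours lie close: a 1.1-fold higher number from compound 1 to compound 3 (0.06 log units; within the scatter) and a 1.5-fold higher number from compound 2 to compound 3 (0.18 log units; within the scatter) are both within the scatter, as is a 1.3-fold lower number from compound 1 to compound 2 (0.12 log units; within the scatter). On these numbers, therefore, none of the three can be told apart.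

Compound 4 `Cc1cc(C)nc(NS(=O)(=O)c2ccc(N/C(S)=N\c3ccnc4cc(C(F)(F)F)ccc34)cc2)n1` is not yet measured. It differs from compound 3 by 4,6-dimethylpyrimidin-2-yl in place of pyrimidin-2-yl on a sulfonamide nitrogen. Within the data shown here, no measured step adds methyl groups to the ring on the sulfonamide nitrogen, so nothing here speaks directly to this change. What the three steps do show is that swapping one ring for another at this position left the number in this assay essentially unchanged, even for compound 1, whose ring already carries two methyl groups. The expectation for compound 4 is thus a step of a 1.1-fold lower number from compound 3 to compound 4 (0.04 log units; within the scatter), not beyond the scatter. Compound 4 is estimated at 38000 nM, within 15000 nM to 95000 nM.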

Compound 4, half-maximal inhibitory concentration: 72200 nM
For compound 4 the middle estimate is 1.9-fold (0.28 log units) below the measured one; low and high end bracket the measured number.
By their numbers in this assay, from the lowest: compounds 2, 1, 3 and 4 (each within the scatter of the next, the first and the last beyond it).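

In this assay, placing two methyl groups on the pyrimidin-2-yl ring gives a 1.7-fold higher number from compound 3 to compound 4 (0.23 log units; within the scatter), so this change alone cannot be told apart from no change, and a 2.0-fold higher number from compound 1 to compound 4 (0.29 log units; within the scatter) also stays within the scatter. Even so, the group on the sulfonamide nitrogen now yields its first step beyond the scatter, a modest one: a 2.6-fold higher number from compound 2 to compound 4 (0.41 log units; beyond the scatter), with 4,6-dimethylpyrimidin-2-yl in place of pyridin-2-yl. No measurement available here offers an explanation for that step.

On these data alone, whether a single methyl group on the pyrimidin-2-yl ring would behave like the two in compound 4 remains open. So does the outcome of putting an amine or a carboxylic acid on that ring, or of replacing the ring on the sulfonamide nitrogen with a plain hydrogen or an open carbon chain.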